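Hydroxy in place of chloro on the aryl carbamoyl arm

The source may hold more compounds than are shown below. What is called first, only, known or untested is meant among the compounds shown, and "the series" means these compounds.

Measured compounds: compound 1 `COc1cc(NC(C)CCCNC(=O)NNC(=O)Nc2ccc(F)cc2)c2ncccc2c1`; compound 2 `COc1cc(NC(C)CCCNC(=O)NNC(=O)Nc2ccc(Cl)cc2)c2ncccc2c1`; compound 3 `COc1cc(NC(C)CCCNC(=O)NNC(=O)Nc2cccc(F)c2)c2ncccc2c1`; not yet measured: compound 4 `COc1cc(NC(C)CCCNC(=O)NNC(=O)Nc2ccc(O)cc2)c2ncccc2c1`.

In a functional assay on NCI-H460 cells (Homo sapiens) for inhibition, read by MTT assay, with a stated time of 72 h (on this read-out lower numbers stand for stronger inhibition and higher numbers for weaker inhibition), compound 1 gives only a limit, > 100000 nM. Compound 2 gives 63000 nM and compound 3 gives 50000 nM; compound 2 sits with the larger of the two numbers, separated only by a 1.3-fold lower number from compound 2 to compound 3 (0.10 log units; within the scatter). Compound 4 differs from compound 2 by hydroxy in place of chloro on an aromatic carbon. For the measured compounds named here, the only step touching the same aromatic carbon is an at least 1.5-fold lower number from compound 1 to compound 2 (0.20 log units; that floor lies within the scatter), whose floor lies within the scatter; no measured step exchanges chloro for hydroxy. Nothing therefore points to a step beyond the scatter, and compound 4 is expected near compound 2, at a 1.1-fold higher number from compound 2 to compound 4 (0.05 log units; within the scatter). Compound 4 is estimated at 70000 nM, between 25000 nM and 200000 nM.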

Compound 4, half-maximal inhibitory concentration: > 100000 nM
Compound 4 gave a limit, no number (the forecaster's own chance of this, stated with the estimate: 35%); middle value at least 1.4-fold (0.15 log units) from the limit.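

In this assay compound 4 gives only a limit, so hydroxy joins fluoro in compound 1 as a second group on this aromatic carbon that ends at the limit: the limit of > 100000 nM in this assay, at which 2 of the 4 values shown sit.

Chloro to hydroxy reads as an at least 1.5-fold higher number from compound 2 to compound 4 (0.20 log units; that floor lies within the scatter), and the change of aryl arm reads as an at least 2.0-fold higher number from compound 3 to compound 4 (0.30 log units; that floor lies within the scatter), so neither step is shown to exceed the scatter. The step between the two limits cannot be read.

From the compounds shown here alone, whether an amine or a carboxylic acid on this carbon would give a number stays open. Going by these compounds, how far compound 1 and compound 4 truly lie past the limit also stays open.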